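This account rests on a few compounds, and the source may have more. Where it says the series, first, only, none or still open, it means among the compounds named here.

Three compounds share one core and differ only in the group carried on the saturated chain carbon bound to an aromatic carbon. Compound 1 `O=c1cc(-n2cc(CSc3ccccc3)nn2)c2cc(Br)ccc2o1` gives 3510 nM in a functional assay on A549 cells (Homo sapiens) for antiproliferative activity, read by MTT assay, with a stated time of 48 h; a lower number here means a stronger inhibitor, a higher number a weaker inhibitor. Compound 2 `O=c1cc(-n2cc(COc3cccnc3)nn2)c2cc(Br)ccc2o1` gives 24800 nM in this assay, and the step of a 7.1-fold higher number from compound 1 to compound 2 (0.85 log units; beyond the scatter) is the only one that joins two measured compounds differing in a single place. Compound 3 `COC(=O)c1ccccc1OCc1cn(-c2cc(=O)oc3ccc(Br)cc23)nn1` gives 5250 nM in this assay; it stands second highest of the three numbers, its value and that of compound 1 lying within the scatter of each other, while compound 2 sits well above it, beyond the scatter.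

Compound 4 `O=c1cc(-n2cc(COc3ccccc3O)nn2)c2cc(Br)ccc2o1` differs from compound 3 by hydroxy in place of methoxycarbonyl on an aromatic carbon. Among the compounds with values here, no measured step alters a substituent on the chain-linked ring in this way: the single measured step replaces the whole group on the chain and was of modest size, so it offers only a loose guide to how far such a change may move the number in this assay. Compound 1 and compound 3 carry quite different groups on the chain yet sit within the scatter of each other. The step of a 1.1-fold lower number from compound 3 to compound 4 (0.02 log units; within the scatter) is therefore expected to stay within the scatter, with no clear direction. Compound 4 is estimated at 5000 nM, in the range 1600 nM to 16000 nM.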

Compound 4, half-maximal inhibitory concentration: 7940 nM
The estimate for compound 4 lay 1.6-fold (0.20 log units) below the measured number; low and high end bracket the measured number.
By their numbers in this assay, from the lowest: compounds 1, 3 and 4 (each within the scatter of the next, the first and the last beyond it); then compound 2.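

Hydroxy in place of methoxycarbonyl, on an aromatic carbon of a six-membered aromatic ring of carbon only and ortho to a large group, gives a 1.5-fold higher number from compound 3 to compound 4 (0.18 log units; within the scatter) in this assay, so this is the first measured sign that this place can take two such different groups without a readable change in the number. The group on the saturated chain carbon still counts, however: 2-hydroxyphenyl in place of pyridin-3-yl on the oxygen gives a 3.1-fold lower number from compound 2 to compound 4 (0.49 log units; beyond the scatter), and 2-hydroxyphenoxy in place of phenylsulfanyl gives a 2.3-fold higher number from compound 1 to compound 4 (0.35 log units; beyond the scatter), both beyond the scatter. Nothing available explains any of these differences in the number.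

On these data alone, whether an amine or a carboxylic acid on this same aromatic carbon would also stay within the scatter of compound 3 remains open. So does whether a longer chain in place of the saturated chain carbon would move the number, and whether these steps would hold on any core other than the shared one.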